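Adding a second methyl to the amino acid chain

The source may report more compounds than this note shows. Statements on the series, on what has been measured and on what is new or still open speak of the compounds shown alone.

- compound 1 `COc1cc(OC)c(/C=C/S(=O)(=O)Nc2ccc(OC)c(NCC(=O)O)c2)c(OC)c1` – 10000 ug/mL
- compound 2 `COc1cc(OC)c(/C=C/S(=O)(=O)Nc2ccc(OC)c(NC(C)C(=O)O)c2)c(OC)c1` – 10000 ug/mL

In a physicochemical assay for solubility (a higher number here means a more soluble compound, a lower number a less soluble compound), compound 2 gives 10000 ug/mL and stands level with compound 1 at 10000 ug/mL on these numbers. Compound 3 `COc1cc(OC)c(/C=C/S(=O)(=O)Nc2ccc(OC)c(NC(C)(C)C(=O)O)c2)c(OC)c1` differs from compound 2 by methyl in place of hydrogen on a saturated chain carbon bound to a carbonyl carbon, a nitrogen on an aromatic ring and a saturated chain carbon with methyl in place of hydrogen on a saturated chain carbon bound to a carbonyl carbon, a nitrogen on an aromatic ring and a saturated chain carbon. For the measured compounds named here, one measured step bears on this, also a methyl in place of hydrogen on that chain carbon, and it showed no change at the digits printed from compound 1 to compound 2 (within the scatter) in this assay as its full size. On that single step, the expected no change at the digits printed from compound 2 to compound 3 (within the scatter) stays within the usual scatter. The estimate for compound 3 is 10000 ug/mL with an expected range from 5000 ug/mL to 12000 ug/mL in this assay for now.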

Compound 3, solubility: 10000 ug/mL
Beside the measured number, compound 3's estimate shows no gap at the digits printed, and the stated range covers the measured number.
By their numbers in this assay, from the lowest: compounds 1, 2 and 3 (each within the scatter of the next).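

In this assay, a second methyl on this chain carbon gives no change at the digits printed from compound 2 to compound 3 (within the scatter), so the step that looked neutral once also reads as neutral when repeated. Taken whole, replacing carboxymethyl with 1-carboxy-1-methylethyl on the nitrogen gives no change at the digits printed from compound 1 to compound 3 (within the scatter), so hydrogen, one methyl and two methyls on this carbon all read alike here. Nothing available explains this sameness. Still open, as far as these compounds go, is whether a longer chain such as ethyl on this carbon would read the same in this assay. An amine in place of the carboxylic acid also remains an open question.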